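Configuration swap at the chain stereocentre

The source may hold more compounds than are shown below. What is called first, only, known or untested is meant among the compounds shown, and "the series" means these compounds.

Compound 1 `N#Cc1cnn(-c2ccccc2)c1NC(=O)C(=O)Nc1c(C#N)cnn1-c1ccccc1` gives 41% in a functional assay on the whole organism (strain Wistar albino) for inhibition, with Rattus norvegicus as the target, read by paw edema, in the formalin test, with stated times of 1 h and 2 h, at a dose of 20 mg/kg by the oral route; a higher number here means more inhibition at the dose given (going by the name of the read-out), a lower number less inhibition. Compound 2 `CC(NC(=O)C(=O)Nc1c(C#N)cnn1-c1ccccc1)c1ccccc1` gives 27% in this assay. Compound 3 `C[C@@H](NC(=O)C(=O)Nc1c(C#N)cnn1-c1ccccc1)c1ccccc1` gives 36% in this assay, the second highest of the three numbers, within the scatter of both compound 1 and compound 2. Within the data shown here, compound 4 `C[C@H](NC(=O)C(=O)Nc1c(C#N)cnn1-c1ccccc1)c1ccccc1` is not yet measured. the two compounds have the same atoms and bonds and differ only in configuration as drawn: 1 of 1 stereo elements differ; a stereocentre at a saturated chain carbon is drawn R in compound 3 and S in compound 4 The only measured step that bears on this change is a number 9 percentage points higher from compound 2 to compound 3 (within the scatter), a pair that differs in the fact that one of compounds 2 and 3 is drawn with a defined configuration and the other without, at the place where they differ; that step stayed within the scatter. No step beyond the scatter is therefore expected in this assay for the mirror configuration either. Compound 4 is expected to give about 28%, from 15% to 42%. The expected step is a number 8 percentage points lower from compound 3 to compound 4 (within the scatter), inside the usual scatter.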

Compound 4, a percentage reported as inhibition, in the whole organism at one dose (the size of the read-out at that dose, not a potency): 32%
Compound 4: middle estimate off by 4 percentage points, on the low side; low and high end bracket the measured number.
By their numbers in this assay, from the lowest: compounds 2, 4, 3 and 1 (each within the scatter of the next, the first and the last beyond it).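

With both drawn configurations now available, the saturated chain carbon can be compared directly in this assay: a number 4 percentage points lower from compound 3 to compound 4 (within the scatter). The R and S forms are therefore not separated at this dose, so inverting this stereocentre produces no step beyond the scatter. The form drawn without a configuration is not separated from the S form either, with a number 5 percentage points higher from compound 2 to compound 4 (within the scatter), matching its earlier comparison with the R form.

On these data alone, whether a longer chain or a carboxylic acid at this carbon would give a step beyond the scatter remains open. So does whether the R and S forms would separate at another dose.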